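Stability of a fluorinated carboxyphenyl analogue in liver microsomes

The source may hold more compounds than are shown below. What is called first, only, known or untested is meant among the compounds shown, and "the series" means these compounds.

Compound 1 `Cc1c(OCCCCOc2ccc(C(=O)O)cc2)ccc(C(=O)CC(C)C)c1O` is tested in an ADME assay (liver) for metabolic stability, with Liver microsome (Rattus norvegicus) as the target, read by LC-MS, using microsomes and NADPH, with stated times of 5 min and 60 min, tested at 4 uM (on this read-out lower numbers stand for a less stable compound and higher numbers for a more stable compound), where compound 1 gives 66%. Compound 2 `Cc1c(OCCCCOc2ccc(C(=O)O)c(Cl)c2)ccc(C(=O)CC2CCCC2)c1O` gives 67% in this assay, a number lying within the usual scatter of that of compound 1, so the two compounds cannot be told apart here. Compound 3 `Cc1c(OCCCCOc2ccc(F)c(C(=O)O)c2)ccc(C(=O)CC(C)C)c1O` differs from compound 1 by 3-carboxy-4-fluorophenyl in place of 4-carboxyphenyl on an oxygen on a saturated carbon. Going by the values given here, no measured pair shows this change, so no step beyond the scatter is expected in this assay. Compound 3 is expected to give 64%, within a range from 48% to 78%. The step of a number 2 percentage points lower from compound 1 to compound 3 (within the scatter) is estimated to stay within the scatter.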

Compound 3, percent of the compound remaining: 59%
Estimate against measurement, compound 3: 5 percentage points above; the range from low to high includes it.
By their numbers in this assay, from the lowest: compounds 3, 1 and 2 (each within the scatter of the next).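

In this assay, putting 3-carboxy-4-fluorophenyl in place of 4-carboxyphenyl on an oxygen on a saturated carbon gives a number 7 percentage points lower from compound 1 to compound 3 (within the scatter), so compound 1 and compound 3 cannot be told apart. Going by these compounds alone, this is the first pair here that differs in one place, and it shows that this swap leaves the read-out within the usual scatter. No measurement shown here bears on the reason for this result.

These compounds cannot separate the added fluorine from the new place of the carboxylic acid. As far as these compounds go, how an amide or a tetrazole in place of that acid would behave remains open.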